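The source may hold more compounds than are shown below. What is called first, only, known or untested is meant among the compounds shown, and "the series" means these compounds.

Measured compounds:

compound 1 `COc1ccc(C2N=C(SCc3ccc(Cl)cc3)NC(C)=C2C(=O)Nc2ccc(F)cc2)cc1OC` — 20.1%
compound 2 `COc1ccc(C2N=C(SCc3ccc(F)cc3)NC(C)=C2C(=O)Nc2ccc(F)cc2)cc1OC` — 22.2%
compound 3 `COc1ccc(C2N=C(SCc3ccc(Cl)cc3)NC(C)=C2C(=O)Nc2ccc(Br)cc2)cc1` — 22.7%

All three were run in a functional assay on the whole organism (artery, strain albino) with Rattus norvegicus as the target, with a stated time of 180 min, at a dose of 10 mg/kg by the oral route; a lower number here means less inhibition, a higher number more inhibition at the dose given (going by the name of the read-out). Compound 1 and compound 2 share one core and differ only in fluoro in place of chloro on an aromatic carbon; in this assay that change gives a number 2.1 percentage points higher from compound 1 to compound 2 (within the scatter). Among the compounds with values here, compound 3 carries a different core from compound 1; how the two cores differ is not broken down here, and the pair shows only that compound 3 gives 22.7% where compound 1 gives 20.1%, two numbers that lie within the usual scatter of each other. No ordering among the three measured compounds can be read from these values.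

Compound 4 `COc1ccc(C2N=C(SCc3ccc(F)cc3)NC(C)=C2C(=O)Nc2ccc(Br)cc2)cc1` is not yet measured. It stands to compound 3 as compound 2 stands to compound 1: the change is fluoro in place of chloro on an aromatic carbon, and the place of the change reads the same, word for word, in both pairs, so it is the same change made on the second core. Within the data shown here, the only measured instance of this change is the one from compound 1 to compound 2, and it moved the read-out by a number 2.1 percentage points higher from compound 1 to compound 2 (within the scatter), a shift within the scatter. On that basis the step from compound 3 to compound 4 in this assay is expected to be a number 1.8 percentage points higher from compound 3 to compound 4 (within the scatter), again within the scatter. The estimate rests on a single pair, so it is held loosely. Compound 4 is therefore estimated at 24.5% in this assay, with an expected range from 13% to 36%.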

Compound 4, a percentage reported as inhibition, in the whole organism at one dose (the size of the read-out at that dose, not a potency): 17%
The estimate for compound 4 lay 7.5 percentage points above the measured number; measured number inside the range.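

In this assay, replacing 4-chlorobenzyl with 4-fluorobenzyl on the core of compound 3 gives a number 5.7 percentage points lower from compound 3 to compound 4 (within the scatter). Set beside the same change on the core of compound 1, the new step does not separate from the earlier one: the same change on two cores in this assay, a number 2.1 percentage points higher (within the scatter) from compound 1 to compound 2 and a number 5.7 percentage points lower (within the scatter) from compound 3 to compound 4, 7.8 percentage points apart, within the scatter of two such steps These two pairs therefore give no sign that the change behaves differently on the two cores, and the opposite directions of the steps carry no weight, but they do not show that it transfers with a fixed size or direction, nor that it has any effect of its own on either core.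

The compounds shown keep chloro or fluoro at this place on the benzyl ring, so it remains open whether a nitrile, an amine or a carboxylic acid there, or a longer chain in place of the benzyl group, would give a step that stands clear of the scatter. Also open, going by these compounds, is whether the fluoro and chloro pairs would separate at another dose or time, as each compound here is represented by a single reading at one dose and one time.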